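This account rests on a few compounds, and the source may have more. Where it says the series, first, only, none or still open, it means among the compounds named here.

Measured so far in an ADME assay on microsomes from liver (Mus musculus) for metabolic stability; a higher number here means faster removal of the compound, a lower number slower removal:
- compound 1 `COc1cc([C@](O)(CCN(C)C)[C@@H](c2cc3cc(Br)ccc3nc2OC)c2ccnc(OC)c2OC)cc(OC2CCC2)n1`: 4.6 uL/min
- compound 2 `COc1cc([C@](O)(CCN(C)C)[C@@H](c2cc3cc(C#N)ccc3nc2OC)c2cccc(C)c2F)cc(OC(F)F)n1`: 5.9 uL/min
- compound 3 `COc1cc([C@](O)(CCN(C)C)[C@@H](c2cc3cc(Br)ccc3nc2OC)c2ccnc(OC)c2OC)cc(OC(F)F)n1`: 4.9 uL/min

Compound 3 stands second highest of the three numbers in this assay, but its nearest neighbour is compound 1 and its furthest is compound 2, and both gaps fall within the scatter, so the three measured compounds sit together in one narrow band and no order among them can be claimed.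

Going by the values given here, the only single-point step measured so far is a 1.1-fold higher number from compound 1 to compound 3 (0.03 log units; within the scatter). Among the compounds with values here, it concerns a different part of the molecule from the change now under consideration, so it does not bear on it directly; it shows only that a change at that oxygen left the clearance number where it was.

Compound 4 `COc1cc([C@](O)(CCN(C)C)[C@@H](c2cc3cc(C#N)ccc3nc2OC)c2ccnc(OC)c2OC)cc(OC(F)F)n1` differs from compound 3 as follows: cyano in place of bromo on an aromatic carbon. Within the data shown here, compound 2 also carries cyano at that place, but it differs from compound 3 in a second position as well, so no clean step is available; what can be said is that compound 2 and compound 3 give values within the scatter of each other.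

On this basis no step beyond the scatter is expected, a 1.1-fold higher number from compound 3 to compound 4 (0.03 log units; within the scatter). The estimate for compound 4 in this assay is 5.2 uL/min, with a range from 3 uL/min to 9 uL/min.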

Compound 4, intrinsic clearance in a liver preparation (reported as CLH), per the amount of preparation that the assay uses: 11 uL/min
Compound 4: the middle estimate sits 2.1-fold (0.33 log units) below what was measured; the measured number lies above the stated range.
By their numbers in this assay, from the lowest: compounds 1, 3, 2 and 4 (each within the scatter of the next, the first and the last beyond it).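

Working notes on the series: at the aromatic carbon of the six-membered carbon-only ring in the fused system, cyano in place of bromo gives the first single-place step beyond the scatter in this assay (a 2.2-fold higher number from compound 3 to compound 4 (0.35 log units; beyond the scatter)), though a modest one, whereas the step at the oxygen stayed within it (a 1.1-fold higher number from compound 1 to compound 3 (0.03 log units; within the scatter)). With cyano held in place, 2,3-dimethoxypyridin-4-yl in place of 2-fluoro-3-methylphenyl stays within the scatter (a 1.9-fold higher number from compound 2 to compound 4 (0.27 log units; within the scatter)), so that exchange cannot be read as a real shift in this assay. Nothing available gives a reason for the bromo to cyano step.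

From the compounds shown here alone, the step rests on a single pair, carrying 2,3-dimethoxypyridin-4-yl and the difluoromethyl group on the oxygen, so whether it holds with 2-fluoro-3-methylphenyl or with cyclobutyl on that oxygen stays open. Also open, going by these compounds, is where other groups on the same aromatic carbon, such as chloro, methoxy or an amine, would fall relative to bromo and cyano in this assay under the same conditions.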